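Working notes: compound 3 to compound 4

This account rests on a few compounds, and the source may have more. Where it says the series, first, only, none or still open, it means among the compounds named here.

Measured in a functional assay on A549 cells (Homo sapiens) for cytotoxicity, read by MTT assay, with a stated time of 48 h; on this read-out higher numbers stand for weaker inhibition and lower numbers for stronger inhibition:
- compound 1 `C=C1C(=O)O[C@H]2CC3=C[C@H](C/C(C)=C/[C@@H](OC(=O)/C=C/c4ccc(N(C)C)cc4)[C@H]12)OC3=O`: > 10000 nM (a limit)
- compound 2 `C=C1C(=O)O[C@H]2CC3=C[C@H](C/C(C)=C/[C@@H](OC(=O)CCl)[C@H]12)OC3=O`: > 10000 nM (a limit)
- compound 3 `C=C1C(=O)O[C@H]2CC3=C[C@H](C/C(C)=C/[C@@H](OC(=O)CC4CCCCC4)[C@H]12)OC3=O`: 6900 nM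

Going by the values given here, compound 3 gives 6900 nM, the only number in the set. Compound 1 and compound 2 offer only (the limit of > 10000 nM in this assay, at which 2 of the 3 values shown sit).

Compound 4 `C=C1C(=O)O[C@H]2CC3=C[C@H](C/C(C)=C/[C@@H](OC(=O)C4CCC(F)(F)CC4)[C@H]12)OC3=O` carries 4,4-difluorocyclohexyl in place of cyclohexylmethyl on a carbonyl carbon.

Two measured steps changed the group on this same carbonyl carbon: an at least 1.4-fold lower number from compound 1 to compound 3 (0.16 log units; that floor lies within the scatter) and an at least 1.4-fold lower number from compound 2 to compound 3 (0.16 log units; that floor lies within the scatter). Both are floors within the scatter and set no direction for the next change. The expected 1.2-fold higher number from compound 3 to compound 4 (0.06 log units; within the scatter) stays within the scatter in this assay. Compound 4 is estimated at 8000 nM, with an expected range of 4000 nM to 14000 nM.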

Compound 4, half-maximal inhibitory concentration: 6400 nM
The estimate for compound 4 lay 1.3-fold (0.10 log units) above the measured number; measured number inside the range.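

In this assay, a second six-membered non-aromatic ring group on this carbonyl carbon gives a 1.1-fold lower number from compound 3 to compound 4 (0.03 log units; within the scatter), so 4,4-difluorocyclohexyl and cyclohexylmethyl cannot be told apart here. Against the other two groups, the steps read an at least 1.5-fold lower number from compound 2 to compound 4 (0.19 log units; that floor lies within the scatter) and an at least 1.5-fold lower number from compound 1 to compound 4 (0.19 log units; that floor lies within the scatter), and neither floor sets an order. Compound 1 and compound 2 still offer no number: the limit of > 10000 nM in this assay, at which 2 of the 4 values shown sit.

On these data alone, whether any group on this carbonyl carbon moves the number beyond the scatter stays open. A phenyl, a primary amine or a carboxylic acid at the end of a longer chain would test this.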